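Phenoxy in place of isobutoxy at the assay ceiling

The source may report more compounds than this note shows. Statements on the series, on what has been measured and on what is new or still open speak of the compounds shown alone.

Compound 1 is `CCOC(=O)CCCCCOc1cccc(CN(C(=O)c2ccc(-c3cccc(N(C)C)c3)cc2)C(C)C)c1`. In an ADME assay on Raji cells (Homo sapiens) for cytotoxicity, read by CellTiter-Glo and resazurin assay, with a stated time of 72 h (a lower number here means that less compound is needed, a higher number that more compound is needed for the effect), compound 1 gives > 26000 nM, which is a limit of the assay and not a number.
Compound 2 is `CCOC(=O)CCCCCOc1cccc(CN(C(=O)c2ccc(-c3cccc(C(C)=O)c3)cc2)C(C)C)c1`. In this assay compound 2 gives > 26000 nM, again a limit.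
Compound 3 is `CCOC(=O)CCCCCOc1cccc(CN(C(=O)c2ccc(-c3cccc(OCC(C)C)c3)cc2)C(C)C)c1`. In this assay compound 3 gives > 26000 nM, also a limit.

Compound 3 therefore stands where every value shown sits: the limit of > 26000 nM in this assay, at which 3 of the 3 values shown sit. The steps a step that the two limits leave unreadable from compound 1 to compound 2, a step that the two limits leave unreadable from compound 1 to compound 3 and a step that the two limits leave unreadable from compound 2 to compound 3 are each hidden by these limits, so their sizes cannot be read. Compound 4 is `CCOC(=O)CCCCCOc1cccc(CN(C(=O)c2ccc(-c3cccc(Oc4ccccc4)c3)cc2)C(C)C)c1` and differs from compound 3 by phenyl in place of isobutyl on an oxygen on an aromatic ring. Among the compounds with values here, with no measured step of readable size, no change beyond the scatter can be foreseen in this assay in either direction. The expected step is a step that the limit leaves unreadable from compound 3 to compound 4. Compound 4 is estimated at 35000 nM, within 15000 nM to 150000 nM, and most likely reported again as a limit.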

Compound 4, half-maximal effective concentration: > 19600 nM
Compound 4: no number, only a limit; the forecaster's own chance of this, stated with the estimate: 85%; the middle value is on the limit's open side.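

Within the data shown here, compound 1, compound 2, compound 3 and compound 4 all give limits and not numbers in this assay, so no step among them can be read. The compounds shown leave open whether these aromatic-ring groups differ in their effect on the cells.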